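Swapping Amino for Nitro on a Benzimidazole Aniline Ring

The source may hold more compounds than are shown below. What is called first, only, known or untested is meant among the compounds shown, and "the series" means these compounds.

Measured compounds:
- compound 1, `COc1ccc(-c2nc3cc(C(F)(F)F)ccc3[nH]2)c(N)c1`: >= 100000 nM
- compound 2, `Cn1c(-c2ccc(N)cc2)nc2cc(C(F)(F)F)ccc21`: 85000 nM

Of the compounds shown here, two have been tested in an ADME assay on BHK cells (Mesocricetus auratus) for cytotoxicity, read by MTT assay, with a stated time of 96 h; a higher number here means that more compound is tolerated, a lower number that less compound is tolerated. Compound 1, `COc1ccc(-c2nc3cc(C(F)(F)F)ccc3[nH]2)c(N)c1`, carries an amino group and a methoxy group on the ring attached to the shared core. In this assay compound 1 gives >= 100000 nM, which is a limit of the assay rather than a number, as the limit of >= 100000 nM in this assay, at which 1 of the 2 values shown sits, records. Compound 2, `Cn1c(-c2ccc(N)cc2)nc2cc(C(F)(F)F)ccc21`, has its amino group on a different ring and a methyl on the core; in this assay compound 2 gives 85000 nM. Both values sit at the weakly cytotoxic end of what this assay can report.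

The compound still to be tested is compound 3, `COc1ccc(-c2nc3cc(C(F)(F)F)ccc3[nH]2)c([N+](=O)[O-])c1`. It differs from compound 1 in one place: nitro in place of amino on an aromatic carbon. Going by the values given here, no measured pair here changes an amino group into a nitro group, so the size of the step is unknown. Because compound 1 stands only at a limit, (the limit of >= 100000 nM in this assay, at which 1 of the 2 values shown sits), the expected step from compound 1 to compound 3 in this assay is an at least 1.4-fold lower number from compound 1 to compound 3 (0.15 log units; that floor lies within the scatter), within or close to the usual scatter. Compound 3 is therefore expected to give 70000 nM, somewhere between 25000 nM and 100000 nM.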

Compound 3, half-maximal cytotoxic concentration: 100000 nM
Beside the measured number, compound 3's estimate is 1.4-fold (0.15 log units) below it; the range from low to high includes it.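

Nitro in place of amino on an aromatic carbon, ortho to a large group and meta to a methoxy group, is now a measured change, and in this assay it reads as a number no higher from compound 1 to compound 3 (the limit leaves the size open). Compound 3 gives 100000 nM, so this position can hold the larger nitro group, with its 3 heavy atoms and 0 hydrogen-bond donors, and the compound still sits at the end of this assay where much compound is tolerated. How large the step is cannot be read, because compound 1 stands at a limit of the assay rather than at a number: the limit of >= 100000 nM in this assay, at which 1 of the 3 values shown sits.

The compounds shown leave open how other groups at this same position, such as a nitrile, a carboxylic acid or an acetamide, would fare in this assay, and whether any of them would bring the number down clearly. They also leave open whether nitro in place of amino would give a readable step on compound 2, where the amino group sits on a different ring and the number is not a limit.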